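Carboxy in place of fluoro on compound 2

A few compounds are considered here, and "the series" means these few. Any claim that something is new, unique, unknown or untested is made for them only; others in the source may bear on it.

In a physicochemical assay for solubility, at pH 7.4 (a higher number here means a more soluble compound, a lower number a less soluble compound), compound 2 `NS(=O)(=O)c1ccc(SCCO)c(F)c1` stands highest of the three measured compounds, at 6000 ug/mL. Compound 3 `NS(=O)(=O)c1ccc(SCCCO)c(F)c1` gives 900 ug/mL. For the measured compounds named here, compound 1 `CC(C)(O)CCSc1ccc(S(N)(=O)=O)cc1` gives 400 ug/mL, but it differs from compound 2 in more than one place and so offers no clean step.

Going by the values given here, the one measured step confined to a single place is a 6.7-fold lower number from compound 2 to compound 3 (0.82 log units; beyond the scatter). That step is a modest one, and it lies on the chain, not on an aromatic carbon.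

The change now in view leads to compound 4 `NS(=O)(=O)c1ccc(SCCO)c(C(=O)O)c1`: carboxy in place of fluoro on an aromatic carbon. The group enters ortho to a (2-hydroxyethyl)sulfanyl group and meta to a sulfamoyl group. Among the compounds with values here, no measured compound tests a change at this place, so the chain step serves only as a rough guide to size. On these data alone, the direction rests on the structural change alone and remains untested. A move of about that size or smaller, towards a higher number in this assay, is expected. The estimated step is a 1.7-fold higher number from compound 2 to compound 4 (0.22 log units; within the scatter). For compound 4 the expected value is 10000 ug/mL, with an estimated range of 3000 ug/mL to 30000 ug/mL.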

Compound 4, solubility: 9300 ug/mL
Compound 4: the middle estimate sits 1.1-fold (0.03 log units) above what was measured; low and high end bracket the measured number.
By their numbers in this assay, from the lowest: compound 1; then compound 3; then compounds 2 and 4 (each within the scatter of the next).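

For the compounds shown here, this is the first step at the aromatic carbon ortho to a (2-hydroxyethyl)sulfanyl group and meta to a sulfamoyl group: in this assay carboxy in place of fluoro gives a 1.6-fold higher number from compound 2 to compound 4 (0.19 log units; within the scatter) and so leaves the two compounds inseparable. Going by these compounds alone, the position therefore takes a group of 3 heavy atoms, with 1 hydrogen-bond donor and 1 hydrogen-bond acceptor, in place of a single fluorine without a step that can be read as a change, while the chain step, a 6.7-fold lower number from compound 2 to compound 3 (0.82 log units; beyond the scatter) on the same parent, remains the only single-place step beyond the scatter. Nothing measured on these compounds bears on why the numbers of compound 2 and compound 4 stay together.

The compounds shown leave open whether a primary amide or a methyl ester on this aromatic carbon would stay within the scatter of compound 2 or move away from it. On these data alone, it also remains open whether carboxy in place of fluoro on compound 3, with its longer chain, would give a step of similar size.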